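Methyl on the benzyl group of a chalcone series

A few compounds are considered here, and "the series" means these few. Any claim that something is new, unique, unknown or untested is made for them only; others in the source may bear on it.

Measured so far:
Compound 1, `O=C(/C=C/c1ccc(F)cc1)c1ccc(OCc2ccccc2)cc1`. In a functional assay on HCT-116 cells (Homo sapiens) for inhibition, read by sulforhodamine B assay, with a stated time of 3 days (a higher number here means a weaker inhibitor of growth, a lower number a stronger inhibitor of growth), compound 1 gives > 50000 nM, which is a limit of the assay and not a number.
Compound 2, `O=C(/C=C/c1ccc(F)cc1)c1ccccc1`. In this assay compound 2 gives 4360 nM.
Compound 3, `O=C(/C=C/c1ccc(Cl)cc1)c1ccc(OCc2ccccc2)cc1`. In this assay compound 3 gives > 50000 nM, again a limit and not a number.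

Compound 1 therefore stands at the limit, with no number of its own; it shares this with compound 3, as summed up in the limit of > 50000 nM in this assay, at which 2 of the 3 values shown sit. Going by the values given here, the one readable step is an at least 11-fold lower number from compound 1 to compound 2 (1.05 log units; beyond the scatter), where the benzyloxy is taken away altogether. The step that the two limits leave unreadable from compound 1 to compound 3 gives no size.

Compound 4, `Cc1ccc(COc2ccc(C(=O)/C=C/c3ccc(F)cc3)cc2)cc1`, differs from compound 1 as follows: methyl in place of hydrogen on an aromatic carbon. The benzyloxy stays in place, and its removal is the only change shown to move the number in this assay. Among the compounds with values here, no measured step bears on a methyl added to the benzyl group. The expectation is that compound 4 stays at or near the limit, so the expected step is a step that the limit leaves unreadable from compound 1 to compound 4, none beyond the scatter. The estimate for compound 4 in this assay is 60000 nM, within 20000 nM to 200000 nM.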

Compound 4, concentration for 50% growth inhibition: > 50000 nM
Compound 4 ended at the assay's limit (the forecaster's own chance of this, stated with the estimate: 75%); the middle value does not contradict the limit.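

In this assay compound 4 gives > 50000 nM as a limit and not a number. Going by these compounds alone, with compound 1 also at a limit, no step between compound 1 and compound 4 can be read: the limit of > 50000 nM in this assay, at which 3 of the 4 values shown sit.

The compounds shown leave open whether benzyl to 4-methylbenzyl changes growth inhibition at all.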